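The source may report more compounds than this note shows. Statements on the series, on what has been measured and on what is new or still open speak of the compounds shown alone.

Working notes on the catechol vinyl sulfone series. Compound 1 `O=S(=O)(/C=C/c1ccc(O)c(O)c1)CC1CCC1` and compound 2 `CCCCCS(=O)(=O)/C=C/c1ccc(O)c(O)c1` share the same core and differ only in the saturated chain on the sulfonyl sulfur. In a functional assay, read by fluorescence and spectrophotometry, with a stated time of 1 h (on this read-out lower numbers stand for an effect already at smaller amounts and higher numbers for an effect only at larger amounts of compound), compound 1 gives 8800 nM, and compound 2 gives 8100 nM. The step of a 1.1-fold lower number from compound 1 to compound 2 (0.04 log units; within the scatter) shows that exchanging the group on this chain carbon left the read-out unchanged. Compound 2 thus holds the lowest of the two numbers, but only within the scatter of compound 1, so no order between them is claimed.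

Compound 3 `O=S(=O)(/C=C/c1ccc(O)c(O)c1)CCCCCCCCCCCO` carries a longer chain: 6-hydroxyhexyl in place of hydrogen on a saturated chain carbon, five bonds along the chain from a sulfonyl sulfur. Among the compounds with values here, the only measured step on this chain, from compound 1 to compound 2, lay within the scatter, so the sole precedent points to no change beyond the scatter, though the new change is larger than that precedent and the added hydroxyl has no measured counterpart here. The step is expected to be a 1.0-fold lower number from compound 2 to compound 3 (0.01 log units; within the scatter). For compound 3 in this assay the estimate is 8000 nM, with a range from 2500 nM to 25000 nM.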

Compound 3, half-maximal effective concentration: 22600 nM
Estimate against measurement, compound 3: 2.8-fold (0.45 log units) below; low and high end bracket the measured number.
By their numbers in this assay, from the lowest: compounds 2 and 1 (each within the scatter of the next); then compound 3.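

In this assay, the chain on the sulfonyl sulfur proves able to move the read-out: 6-hydroxyhexyl in place of hydrogen, five bonds along the chain from a sulfonyl sulfur, gives a 2.8-fold higher number from compound 2 to compound 3 (0.45 log units; beyond the scatter), a modest step, whereas the exchange between compound 1 and compound 2 stayed within the scatter. The direction is towards an effect only at larger amounts of compound, so this extension brings no gain on the read-out. Nothing available explains the shift.

Compound 3 differs from compound 2 in both chain length and the terminal hydroxyl, so the compounds shown cannot separate these two changes. An undecyl chain without the hydroxyl would address that, and a carboxylic acid or an amine at the chain end would show whether the end group matters.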